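A few compounds are considered here, and "the series" means these few. Any claim that something is new, unique, unknown or untested is made for them only; others in the source may bear on it.

Measured so far in a functional assay on HepG2 cells (Homo sapiens) for antiproliferative activity, read by MTT assay, with a stated time of 48 h; on this read-out higher numbers stand for weaker inhibition and lower numbers for stronger inhibition:
- compound 1 `CCCCOc1ccc(C(=O)/C=C/c2c(/C=C/c3ccc(OC)cc3)cc(OC)cc2OC)cc1`: 12.9 ug/mL
- compound 2 `COc1ccc(/C=C/c2cc(OC)cc(OC)c2/C=C/C(=O)c2ccc(Cl)cc2)cc1`: 13.6 ug/mL

Compound 2 at 13.6 ug/mL and compound 1 at 12.9 ug/mL lie within the scatter of each other, so neither ranks ahead of the other.

The next compound to be read is compound 3 `COc1ccc(/C=C/c2cc(OC)cc(OC)c2/C=C/C(=O)c2ccc(C)cc2C)cc1`. It differs from compound 2 as follows: 2,4-dimethylphenyl in place of 4-chlorophenyl on a carbonyl carbon. In words, 2,4-dimethylphenyl stands in place of 4-chlorophenyl on a carbonyl carbon.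

Among the compounds with values here, only one measured step bears on this change: a 1.1-fold higher number from compound 1 to compound 2 (0.02 log units; within the scatter). It replaced butoxy with chloro on the group that changes here, and the number in this assay stayed within the scatter. Within the data shown here, no measured compound carries 2,4-dimethylphenyl, so this single step is thin support and the range has to stay wide.

On that evidence, no step beyond the scatter is expected. The estimated step is a 1.0-fold lower number from compound 2 to compound 3 (0.02 log units; within the scatter). For compound 3 the expected value is 13 ug/mL, with an estimated range from 7 ug/mL to 25 ug/mL.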

Compound 3, half-maximal inhibitory concentration: 0.9 ug/mL
Estimate against measurement, compound 3: 14-fold (1.16 log units) above; the whole stated range lies above it.
By their numbers in this assay, from the lowest: compound 3; then compounds 1 and 2 (each within the scatter of the next).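

In this assay the aryl group on the carbonyl carbon proves to be a sensitive position: 2,4-dimethylphenyl in place of 4-chlorophenyl gives a 15-fold lower number from compound 2 to compound 3 (1.18 log units; beyond the scatter) and, in place of 4-butoxyphenyl, gives a 14-fold lower number from compound 1 to compound 3 (1.16 log units; beyond the scatter) in the same direction. The earlier exchange of butoxy for chloro (a 1.1-fold higher number from compound 1 to compound 2 (0.02 log units; within the scatter)) gave no sign of this, so the two earlier aryl groups, though very different in size, sit level, and among these three compounds only compound 3, with its 2,4-dimethylphenyl, stands apart as the strongest inhibitor. No measurement at hand accounts for this step.

With both methyl groups entering together, the compounds shown cannot say whether a phenyl ring carrying a single methyl would give the same gain or whether the pair is needed. Also open, on these data alone, is whether the gain holds when ethyl, methoxy, an amine or a carboxylic acid takes the place of the methyl groups on that ring, and whether it carries over to the rest of the shared core with its other substituents changed.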